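Benzoxaborole chalcones: from a phenyl to a carboxy group

This account rests on a few compounds, and the source may have more. Where it says the series, first, only, none or still open, it means among the compounds named here.

Three benzoxaborole chalcones have been measured in a functional assay on MDA-MB-231 cells (Homo sapiens) for cytotoxicity, read by MTT assay, with a stated time of 48 h; a higher number here means a weaker inhibitor, a lower number a stronger inhibitor. Compound 1 `O=C(/C=C/c1ccc2c(c1)B(O)OC2)c1ccc(-c2ccccc2)cc1` gives 6400 nM, the second highest of the three numbers; compound 3 `COc1cc(C(=O)/C=C/c2ccc3c(c2)B(O)OC3)ccc1[N+](=O)[O-]` gives 11400 nM, which lies within the scatter of compound 1, while compound 2 `O=C(/C=C/c1ccc2c(c1)B(O)OC2)c1cccc(O)c1` gives 2700 nM, a lower number beyond the scatter. Compound 4 `O=C(O)c1ccc(C(=O)/C=C/c2ccc3c(c2)B(O)OC3)cc1` has not yet been measured in this assay. It differs from compound 1 in one place: carboxy in place of phenyl on an aromatic carbon. Among the compounds with values here, no measured pair shows this change, so the expected step can only be judged from the spread of the three numbers and from compound 1 at 6400 nM. The authors expect a modest rise in the number from compound 1 to compound 4 of a 1.9-fold higher number from compound 1 to compound 4 (0.27 log units; within the scatter), possibly within the scatter. The estimate for compound 4 in this assay is 12000 nM, within a range from 4000 nM to 40000 nM.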

Compound 4, half-maximal inhibitory concentration: > 100000 nM
Compound 4: only a limit was reported (the forecaster's own chance of this, stated with the estimate: 25%); middle value at least 8.3-fold (0.92 log units) away from the limit.
By their numbers in this assay, from the lowest: compound 2; then compounds 1 and 3 (each within the scatter of the next). At a limit, above all of these: compound 4.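

In this assay, compound 4 gives only a limit, > 100000 nM, and not a number. Within the data shown here, this position therefore does not tolerate every change: replacing phenyl with carboxy gives an at least 15-fold higher number from compound 1 to compound 4 (1.19 log units; beyond the scatter), a large step that none of the earlier compounds could reveal. The true size of this step remains unknown: the limit of > 100000 nM in this assay, at which 1 of the 4 values shown sits.

The compounds shown leave open whether the step comes from losing the phenyl or from gaining the carboxy. A methyl ester or an amide at this position would help separate the two.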